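Moving the Trifluoromethyl Around the Phenyl Ring

This account rests on a few compounds, and the source may have more. Where it says the series, first, only, none or still open, it means among the compounds named here.

Compound 1 `COc1cc(C2=NN(C(C)=O)C(c3ccccc3C(F)(F)F)O2)cc(OC)c1OC` and compound 2 `COc1cc(C2=NN(C(C)=O)C(c3ccc(C(F)(F)F)cc3)O2)cc(OC)c1OC` share one core and carry the same trifluoromethylphenyl group, attached through different ring carbons. Within the data shown here, in a functional assay on PC-3 cells (Homo sapiens) for antiproliferative activity, read by MTT assay, tested at 5 uM (a lower number here means a weaker effect, a higher number a stronger effect of the compound at the concentration tested), compound 1 gives 15.2% and compound 2 gives -0.7%, the lower of the two numbers measured so far, with the step of a number 15.9 percentage points lower from compound 1 to compound 2 (beyond the scatter) as the only change known. Compound 3 `COc1cc(C2=NN(C(C)=O)C(c3cccc(C(F)(F)F)c3)O2)cc(OC)c1OC` differs from compound 2 by 3-(trifluoromethyl)phenyl in place of 4-(trifluoromethyl)phenyl on a saturated ring carbon. That one measured step concerns a different shift of the same group, so only a modest move is expected here. Compound 3 is estimated at 7%, between -8% and 22%. This expected change amounts to a number 7.7 percentage points higher from compound 2 to compound 3 (within the scatter).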

Compound 3, a percentage reported as inhibition, at one concentration (the size of the read-out at that concentration, not a potency): 43.6%
Compound 3: the middle estimate sits 36.6 percentage points below what was measured; measured number above the stated range.
By their numbers in this assay, from the lowest: compound 2; then compound 1; then compound 3.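

Having all three placements shows that where the trifluoromethyl sits on the phenyl ring can matter more than the one earlier step suggested: 3-(trifluoromethyl)phenyl in place of 4-(trifluoromethyl)phenyl gives a number 44.3 percentage points higher from compound 2 to compound 3 (beyond the scatter) and in place of 2-(trifluoromethyl)phenyl gives a number 28.4 percentage points higher from compound 1 to compound 3 (beyond the scatter) in this assay on the shared core. Compound 3 therefore stands highest of the three, even though the atoms are unchanged. Nothing available explains why this placement stands out. As far as these compounds go, whether an amine or a nitrile in the same placement would keep this order remains open, as does how the three compounds rank at other concentrations.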